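Moving the Thiophene Attachment Point on a Shared Core

The compounds below may be only part of what the source reports. "The series", "measured", "known", "first", "only" and "open" are said of these compounds alone.

Of the compounds shown here, three built on one shared core have been measured in an assay on HeLa cells for displacement of a labelled ligand from adenosine receptor A3 (Homo sapiens), with a stated time of 180 min, tested at 1 uM; a lower number here means less inhibition, a higher number more inhibition at the concentration tested (going by the name of the read-out). Compound 1 `CCOC(=O)C1=C(C)N/C(=N\C#N)NC1c1ccsc1` carries a thiophen-3-yl group on a saturated ring carbon and gives 23%. Compound 2 `CC1=C(C(=O)OC(C)C)C(c2ccccc2)N/C(=N/C#N)N1` gives 6% in this assay, and compound 3 `CC1=C(C(=O)OC(C)C)[C@@H](c2ccco2)N/C(=N/C#N)N1` gives 4%. Among these three numbers compound 1 stands highest: the nearest, compound 2, lies below it by a gap beyond the usual scatter, and compound 3 lies further below still. No two of the measured compounds differ in only one place, so no single structural step can be read off from them.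

Compound 4 `CCOC(=O)C1=C(C)N/C(=N\C#N)NC1c1cccs1` has not yet been measured. It differs from compound 1 in one place: thiophen-2-yl in place of thiophen-3-yl on a saturated ring carbon. The two compounds contain the same atoms, joined differently, so the change is only a shift of the point at which the thiophene ring is attached to the core.

Nothing in the measured set shows how such a shift acts in this assay. The expected change is a number 1 percentage points higher from compound 1 to compound 4 (within the scatter), small, in either direction, and most likely within the scatter. Compound 4 is therefore estimated to give about 24% in this assay, with a likely range from 8% to 42%.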

Compound 4, a percentage reported as inhibition, at one concentration (the size of the read-out at that concentration, not a potency): 3%
Estimate against measurement, compound 4: 21 percentage points above; the whole stated range lies above it.
By their numbers in this assay, from the lowest: compounds 4, 3 and 2 (each within the scatter of the next); then compound 1.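

In this assay, moving the point of attachment from thiophen-3-yl to thiophen-2-yl gives a number 20 percentage points lower from compound 1 to compound 4 (beyond the scatter), so the read-out at this saturated ring carbon depends on how the thiophene is joined to the shared core, not only on which ring is present. The earlier compounds shown here could not show this, since no two of them differed in only one place, whereas thiophen-3-yl and thiophen-2-yl have the same atoms and the same counts of hydrogen-bond donors and acceptors, so those counts do not separate compound 1 from compound 4. The data at hand offer no measurement that explains the step.

This single pair cannot show whether the same shift would matter for another ring at this carbon, such as furan-3-yl against the furan-2-yl of compound 3, or whether a thiophen-3-yl carrying a chlorine or a methyl group would keep or change the read-out. The step also rests on one concentration, so it says nothing about how the potencies of compound 1 and compound 4 compare.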